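Pyrazolyl enones on BT-549 cells: next step

This account rests on a few compounds, and the source may have more. Where it says the series, first, only, none or still open, it means among the compounds named here.

Measured so far:
compound 1 `COc1ccc(-c2cc(/C=C/C(=O)c3ccc(OC)c(OC)c3)[nH]n2)cc1`: -99%
compound 2 `COc1ccc(-c2cc(/C=C/C(=O)c3ccc(N)cc3)[nH]n2)cc1OC`: -98%
compound 3 `COc1ccc(C(=O)/C=C/c2cc(-c3cc(OC)c(OC)c(OC)c3)n[nH]2)cc1`: -49%

In a functional assay on BT-549 cells (Homo sapiens) for cytotoxicity, read by sulforhodamine B assay, with a stated time of 48 h, tested at 100 uM (a lower number here means a stronger effect, a higher number a weaker effect of the compound at the concentration tested), compound 3 gives -49%, the highest of the three numbers; the nearest is compound 2, and compound 1 stands furthest off, both beyond the scatter. Compound 4 `COc1cc(-c2cc(/C=C/C(=O)c3ccc(F)c(F)c3)[nH]n2)cc(OC)c1OC` is not yet measured. It differs from compound 3 in one place: 3,4-difluorophenyl in place of 4-methoxyphenyl on a carbonyl carbon. Among the measured compounds shown here, no measured pair shows a step of this kind, so the size cannot be read from the series. Compound 3 sits apart from compound 1 and compound 2, and the expected step from compound 3 to compound 4 is downward, a number 16 percentage points lower from compound 3 to compound 4 (beyond the scatter), with wide uncertainty. Compound 4 is estimated at -65%, range -100% to -20%.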

Compound 4, a percentage reported as activity, at one concentration (the size of the read-out at that concentration, not a potency): -58%
Compound 4: the middle estimate sits 7 percentage points below what was measured; low and high end bracket the measured number.
By their numbers in this assay, from the lowest: compounds 1 and 2 (each within the scatter of the next); then compounds 4 and 3 (each within the scatter of the next).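

In this assay, among the compounds shown here, the exchange of 4-methoxyphenyl for 3,4-difluorophenyl on a carbonyl carbon gives a number 9 percentage points lower from compound 3 to compound 4 (within the scatter) and is the first single-place step. At this place, the two groups are therefore not told apart, although one carries a methoxy oxygen and the other two fluorines. No measured property bears on this result.
Open, going by these compounds, is whether a carboxylic acid or a morpholine at this place would separate from these two groups. Also open, on these data alone, is whether 3,4-difluorophenyl reads the same way on the core of compound 1.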